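The source may report more compounds than this note shows. Statements on the series, on what has been measured and on what is new or still open speak of the compounds shown alone.

Measured so far in an ADME assay on MDCK-II cells (Canis lupus familiaris) for permeability; on this read-out lower numbers stand for lower permeability and higher numbers for higher permeability:
- compound 1 `CC(C)Oc1cc(Oc2ccc(S(C)(=O)=O)cc2)cc(-c2nccc(=O)[nH]2)c1`: 24 10^-6 cm/s
- compound 2 `CC(C)Oc1cc(Oc2ccc(S(C)(=O)=O)cc2)cc(-c2ncc(C(C)C)c(=O)[nH]2)c1`: "not determined" (no result reported)

Compound 2 has no single number to stand on: the entry for compound 2 reads "not determined" (no result reported). The step that follows therefore starts from no measured value, and its size cannot be read directly from the data.

The next structure is compound 3 `CC(C)Oc1cc(Oc2ccc(S(C)(=O)=O)cc2)cc(-c2ncc(Cl)c(=O)[nH]2)c1`. The change is chloro in place of isopropyl on an aromatic carbon, two atoms from the ring nitrogen and para to a large group.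

Within the data shown here, no step between measured compounds exists, so nothing shows how this assay responds to a change at this place. Among the measured compounds shown here, the only number available is that of compound 1, at 24 10^-6 cm/s, and the expectation is anchored on it. No step beyond the usual scatter is expected from that anchor, in either direction.

For compound 3 the expected value is 18 10^-6 cm/s, with an estimated range of 7 10^-6 cm/s to 32 10^-6 cm/s.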

Compound 3, apparent permeability: 8.3 10^-6 cm/s
The estimate for compound 3 lay 2.2-fold (0.34 log units) above the measured number; the range from low to high includes it.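

In this assay, among these compounds, chloro in place of hydrogen on an aromatic carbon, two atoms from the ring nitrogen, gives a 2.9-fold lower number from compound 1 to compound 3 (0.46 log units; beyond the scatter) as the first readable step, a modest one that lies beyond the scatter. The read-out therefore responds to a change at this place, at least for this one substitution on the core of compound 1, and the direction of that response is downward. The exchange of isopropyl for chloro cannot be read as a step since compound 2 carries no number, and no measured property of these compounds bears on the reason for the lower number.

A single step leaves open whether the lower number belongs to chloro or would come with other groups on the same aromatic carbon, such as fluoro, methyl, a nitrile or an amine. Also open, from the compounds shown here alone, is whether any such group would stay within the scatter of compound 1 at 24 10^-6 cm/s and whether isopropyl itself sits above or below chloro on this read-out.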